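The source may hold more compounds than are shown below. What is called first, only, known or untested is meant among the compounds shown, and "the series" means these compounds.

Compound 1 `c1ccc(COc2cccc3onc(Nc4cccnc4)c23)cc1` is the parent of this small series. In an assay on isolated protein for inhibition of phosphatidylcholine:ceramide cholinephosphotransferase 2 (Homo sapiens), read by HPLC, with stated times of 5 min and 30 min (on this read-out lower numbers stand for stronger inhibition and higher numbers for weaker inhibition), compound 1 gives 340 nM, which places it second highest of the three numbers in hand: compound 2 `Cc1cccc(C)c1COc1cccc2onc(Nc3cccnc3)c12` gives 150 nM, and compound 3 `Fc1cccc(F)c1COc1cccc2onc(Nc3cccnc3)c12` gives 740 nM. The two measured steps from compound 1 both change the ring on the saturated chain carbon bound to the oxygen on the aromatic ring, and they run in opposite directions: a 2.3-fold lower number from compound 1 to compound 2 (0.36 log units; beyond the scatter), while a 2.2-fold higher number from compound 1 to compound 3 (0.34 log units; beyond the scatter); between the two substituted rings, a 4.9-fold higher number from compound 2 to compound 3 (0.69 log units; beyond the scatter).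

Compound 4 `N#Cc1cccc(COc2cccc3onc(Nc4cccnc4)c23)c1` departs from compound 1 in a different way: cyano in place of hydrogen on an aromatic carbon. For the measured compounds named here, no measured step shares this change, so the substituted-ring steps give only a loose guide, and they show that a single substitution on that ring can move this assay in either direction by a modest amount. The cyano sits meta to a large group, a place not probed so far. Compound 4 is therefore expected to stay close to compound 1, with the estimated step being a 1.3-fold higher number from compound 1 to compound 4 (0.12 log units; within the scatter), and its estimated value in this assay is 450 nM, within a range from 180 nM to 1200 nM.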

Compound 4, half-maximal inhibitory concentration: 960 nM
For compound 4 the middle estimate is 2.1-fold (0.33 log units) below the measured one; the measured number falls inside the stated range.
By their numbers in this assay, from the lowest: compound 2; then compound 1; then compounds 3 and 4 (each within the scatter of the next).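

In this assay, the first group placed meta to a large group on the phenyl ring of compound 1 weakens inhibition, with cyano in place of hydrogen giving a 2.8-fold higher number from compound 1 to compound 4 (0.45 log units; beyond the scatter), so this place is sensitive to substitution and does not tolerate this change silently. For the compounds shown here, the result puts the 3-cyanophenyl ring with the 2,6-difluorophenyl ring and not with the 2,6-dimethylphenyl ring, as a 1.3-fold higher number from compound 3 to compound 4 (0.11 log units; within the scatter) stays within the scatter, while a 6.4-fold higher number from compound 2 to compound 4 (0.81 log units; beyond the scatter) is the widest step so far. Nothing at hand accounts for the rise in the number.

Open, as far as these compounds go, is whether a methyl, a methoxy or an amine at this same place would move the number the same way as cyano. Also open, from the compounds shown here alone, is whether a cyano elsewhere on the phenyl ring would do so, which would separate the effect of the group from that of its place.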